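This account rests on a few compounds, and the source may have more. Where it says the series, first, only, none or still open, it means among the compounds named here.

Four close relatives built on one shared core are compared in a toxicity assay on HeLa cells (Homo sapiens) for cytotoxicity, read by MTT assay, with a stated time of 24 h; a higher number here means a weaker inhibitor, a lower number a stronger inhibitor. Compound 1 `CCN1CCN(C(=S)SCC(O)Cn2c([N+](=O)[O-])cnc2C)CC1` carries an ethyl group on an amine nitrogen in a ring. In this assay compound 1 reports only a limit, > 5000000 nM. Compound 2 `Cc1ncc([N+](=O)[O-])n1CC(O)CSC(=S)N1CCN(c2ccccn2)CC1` differs from compound 1 by a single change, (pyridin-2-yl in place of ethyl on an amine nitrogen in a ring). In this assay compound 2 gives 2970000 nM. The step this change made is an at least 1.6-fold lower number from compound 1 to compound 2 (0.22 log units; that floor lies within the scatter). Compound 3 `CCN1CCN(CC(O)Cn2cc([N+](=O)[O-])nc2C)CC1` keeps the ethyl group but its core differs from that of compound 1, and the difference between the two cores is not broken down here. In this assay compound 3 also reports only a limit, > 5000000 nM. Compound 4 `Cc1nc([N+](=O)[O-])cn1CC(O)CN1CCN(c2ccccn2)CC1`, not yet measured, stands to compound 3 as compound 2 stands to compound 1, with the same change at the same place, (pyridin-2-yl in place of ethyl on an amine nitrogen in a ring). The shift expected is an at least 1.6-fold lower number from compound 3 to compound 4 (0.22 log units; that floor lies within the scatter), because the earlier shift from a limit to a number was an at least 1.6-fold lower number from compound 1 to compound 2 (0.22 log units; that floor lies within the scatter) and because compound 1 sits at the limit of > 5000000 nM in this assay, at which 2 of the 3 values shown sit. Compound 4 is therefore estimated at 3000000 nM, with a plausible range from 1200000 nM to 6000000 nM.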

Compound 4, half-maximal inhibitory concentration: > 5000000 nM
Compound 4: a limit, no number; the forecaster's own chance of this, stated with the estimate: 40%; at least 1.6-fold (0.22 log units) between middle value and limit.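

In this assay, compound 3 and compound 4 each give only a limit, so no step can be read between them. The compounds shown leave open whether pyridin-2-yl in place of ethyl changes the number at all on the core of compound 3, and how the compounds at this limit rank against one another: the limit of > 5000000 nM in this assay, at which 3 of the 4 values shown sit.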